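Iodine in Place of Bromine: What Compound 4 May Show

A few compounds are considered here, and "the series" means these few. Any claim that something is new, unique, unknown or untested is made for them only; others in the source may bear on it.

Compound 1 `CNc1nc(O)c(Br)c(-c2ccccc2)n1` gives 78% in a functional assay on the whole organism for inhibition, with Rattus norvegicus as the target, at a dose of 50 mg/kg by the oral route; on this read-out higher numbers stand for a stronger effect at the one dose given and lower numbers for a weaker effect.
Compound 2 `Nc1nc(O)c(I)c(-c2ccccc2)n1` gives 3% in this assay.
Compound 3 `Oc1nc(O)c(Br)c(-c2ccccc2)n1` gives 46% in this assay.

Compound 3 stands second highest of the three numbers; compound 1 lies nearest and higher, compound 2 furthest and lower. Within the data shown here, the one step measured in one place, a number 32 percentage points lower from compound 1 to compound 3 (beyond the scatter), concerns a change at another carbon and does not bear directly on the step to compound 4 `Oc1nc(O)c(I)c(-c2ccccc2)n1`, which is iodo in place of bromo on an aromatic carbon. Compound 2 also carries iodo and gives a low number, but it differs from compound 3 in two places, so its value only hints that iodo may weaken the effect. Compound 4 is therefore expected to give 35%, within 10% to 60%, an estimated step of a number 11 percentage points lower from compound 3 to compound 4 (beyond the scatter).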

Compound 4, a percentage reported as inhibition, in the whole organism at one dose (the size of the read-out at that dose, not a potency): 41%
Compound 4: middle estimate off by 6 percentage points, on the low side; low and high end bracket the measured number.
By their numbers in this assay, from the lowest: compound 2; then compounds 4 and 3 (each within the scatter of the next); then compound 1.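

In this assay, iodo in place of bromo on this aromatic carbon gives a number 5 percentage points lower from compound 3 to compound 4 (within the scatter), so with the hydroxy group kept in both compounds, the two halogens cannot be told apart here. Iodo therefore does not by itself go with a low number, since hydroxy in place of amino gives a number 38 percentage points higher from compound 2 to compound 4 (beyond the scatter), and the iodo pair separates widely on that change alone. Nothing at hand explains either step.

Going by these compounds, what chloro or a methyl group would give on this carbon stays open. So does whether iodo would match bromo with methylamino on the shared core.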